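A few compounds are considered here, and "the series" means these few. Any claim that something is new, unique, unknown or untested is made for them only; others in the source may bear on it.

Compound 2, with the structure `Nc1nn(C(=O)Nc2ccc(Cc3ccccc3)cc2)c2ccc(Cl)cc12`, carries a chloro group on the shared core. In a functional assay on Malme-3M cells (Homo sapiens) for antiproliferative activity, read by sulforhodamine B assay, with a stated time of 48 h (a higher number here means that more compound is tolerated, a lower number that less compound is tolerated), compound 2 reaches only the limit of the measurement, > 100000 nM, so no number is known for it. Its nearest neighbour is compound 1, with the structure `Nc1nn(C(=O)Nc2ccc(Cc3ccccc3)cc2)c2ccccc12`, which has a hydrogen where compound 2 has the chloro group. In this assay compound 1 also sits at a limit, > 100000 nM. The step that the two limits leave unreadable from compound 1 to compound 2 therefore cannot be sized, and both values share the same footing, (the limit of > 100000 nM in this assay, at which 2 of the 2 values shown sit).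

Compound 3, with the structure `Nc1ccc2c(c1)c(N)nn2C(=O)Nc1ccc(Cc2ccccc2)cc1`, has not yet been measured. It differs from compound 2 by amino in place of chloro on an aromatic carbon. Going by the values given here, the only measured step on this scaffold is the unreadable one from compound 1 to compound 2, so there is no readable step to build on for the exchange of chloro for amino. With both known values at a limit, compound 3 is expected to give 100000 nM in this assay, between 30000 nM and 300000 nM, which means an expected step of a number no higher from compound 2 to compound 3 (the limit leaves the size open) that most likely again ends at the limit rather than at a number.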

Compound 3, concentration lethal to 50% of the cells: > 100000 nM
Compound 3 gave a limit, no number; the forecaster's own chance of this, stated with the estimate: 80%; the middle value lies on the limit itself.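

Compound 3 also gives a limit and no number, so its steps from compound 2 and from compound 1 cannot be read, and all three compounds stand on the same footing: the limit of > 100000 nM in this assay, at which 3 of the 3 values shown sit.

The compounds shown leave open whether hydrogen, chloro or amino at this place on the shared core makes any difference in this assay.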